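From azepan-1-yl to cyclohexylamino on a sulfonyl sulfur

A few compounds are considered here, and "the series" means these few. Any claim that something is new, unique, unknown or untested is made for them only; others in the source may bear on it.

Values in an ADME assay on Vero cells (Chlorocebus sabaeus) for cytotoxicity, read by MTT assay; a lower number here means that less compound is tolerated, a higher number that more compound is tolerated:
- compound 1 (`O=C(O)c1ccccc1-n1nc(C(F)(F)F)cc1C(=O)Nc1ccc(S(=O)(=O)N2CCCC2)cc1`): "not determined" (no result reported)
- compound 2 (`Cn1nc(C(F)(F)F)cc1C(=O)Nc1ccc(S(=O)(=O)N2CCCCCC2)cc1`): > 300000 nM
- compound 3 (`Cn1nc(C(F)(F)F)cc1C(=O)Nc1ccc(S(=O)(=O)N2CCC(C(F)(F)F)CC2)cc1`): 159000 nM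

Compound 2 stands at a limit of this assay (> 300000 nM), with no single number. Compound 4 (`Cn1nc(C(F)(F)F)cc1C(=O)Nc1ccc(S(=O)(=O)NC2CCCCC2)cc1`) carries cyclohexylamino in place of azepan-1-yl on a sulfonyl sulfur. Going by the values given here, the one measured step bearing on this change is also on a sulfonyl sulfur (an at least 1.8-fold lower number from compound 2 to compound 3 (0.27 log units; that floor lies within the scatter)). On that basis, no step beyond the scatter is expected in this assay, and the estimated step is small (an at least 1.2-fold lower number from compound 2 to compound 4 (0.07 log units; that floor lies within the scatter)). For compound 4 the estimated value is 250000 nM (expected range 100000 nM to 500000 nM).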

Compound 4, half-maximal cytotoxic concentration: 15000 nM
Compound 4: middle estimate off by 17-fold (1.22 log units), on the high side; measured number outside the range, below it.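

In this assay, cyclohexylamino in place of azepan-1-yl on the sulfonyl sulfur gives an at least 20-fold lower number from compound 2 to compound 4 (1.30 log units; beyond the scatter), so this position separates two groups with the same heavy atoms, joined differently. Compound 2 gives only a limit, so that step is a floor: the limit of > 300000 nM in this assay, at which 1 of the 4 values shown sits. Cyclohexylamino in place of 4-(trifluoromethyl)piperidin-1-yl also gives a large step, an 11-fold lower number from compound 3 to compound 4 (1.03 log units; beyond the scatter), which the earlier change, an at least 1.8-fold lower number from compound 2 to compound 3 (0.27 log units; that floor lies within the scatter), did not foreshadow.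

As far as these compounds go, it remains open whether this step follows the added hydrogen-bond donor or the all-carbon ring. A cyclohexyl(methyl)amino group on the same sulfur would separate the two.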